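Extending the side chain from methoxy to an acetyl-bearing chain

The compounds below may be only part of what the source reports. "The series", "measured", "known", "first", "only" and "open" are said of these compounds alone.

Among the measured compounds shown here, in an assay on Cerebral cortex for binding affinity to adenosine receptor A1 (Cavia porcellus), read by radioligand binding (a higher number here means a weaker inhibitor, a lower number a stronger inhibitor), compound 3 `CCCn1c(=O)n(CCOC)c(=O)c2[nH]cnc21` gives 2500 nM, the lowest of the three numbers measured so far. Compound 1 `CCCn1c(=O)n(CCC(N)=O)c(=O)c2[nH]cnc21` gives 31500 nM and compound 2 `CCCn1c(=O)n(CCO)c(=O)c2[nH]cnc21` gives 50000 nM; the step of a 1.6-fold higher number from compound 1 to compound 2 (0.20 log units; within the scatter) does not separate these two. The two steps that reach compound 3 were both large: a 13-fold lower number from compound 1 to compound 3 (1.10 log units; beyond the scatter) and a 20-fold lower number from compound 2 to compound 3 (1.30 log units; beyond the scatter). Both replace a group with a hydrogen-bond donor by one that has only an acceptor, and the number falls.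

Compound 4 `CCCn1c(=O)n(CCCCC(C)=O)c(=O)c2[nH]cnc21` differs from compound 3 by 2-acetylethyl in place of methoxy on a saturated chain carbon, two bonds along the chain from an aromatic nitrogen. For the measured compounds named here, the acceptor is kept, no donor is added, but the chain is extended well beyond anything measured here, so no step speaks directly to the length. Because a 20-fold lower number from compound 2 to compound 3 (1.30 log units; beyond the scatter) and a 13-fold lower number from compound 1 to compound 3 (1.10 log units; beyond the scatter) reward removing the donor rather than any particular acceptor, compound 4 is expected to stay near compound 3, perhaps slightly weaker, a step of a 2.0-fold higher number from compound 3 to compound 4 (0.30 log units; within the scatter) in this assay. Compound 4 is therefore estimated at 5000 nM, with a range from 1500 nM to 20000 nM.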

Compound 4, inhibition constant: 23100 nM
Estimate against measurement, compound 4: 4.6-fold (0.66 log units) below; measured number above the stated range.
By their numbers in this assay, from the lowest: compound 3; then compounds 4, 1 and 2 (each within the scatter of the next, the first and the last beyond it).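

In this assay, neither methoxy nor 2-acetylethyl carries a hydrogen-bond donor, yet the number still rises in a 9.2-fold higher number from compound 3 to compound 4 (0.97 log units; beyond the scatter), so at this place on a saturated chain carbon, lacking a donor is not enough to keep the low number of compound 3. The new group gives up most of that advantage: a 1.4-fold lower number from compound 1 to compound 4 (0.13 log units; within the scatter) does not separate it from the carbamoyl compound, and a 2.2-fold lower number from compound 2 to compound 4 (0.34 log units; beyond the scatter) leaves it only modestly apart from the hydroxy compound. Nothing available here accounts for this rise.

The compounds shown do not separate the length of the chain from its ketone carbonyl, as neither a plain pentyl chain nor a shorter acetyl-bearing chain stands among them. As far as these compounds go, how an amine or a carboxylic acid would read at this place also remains open.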